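Aryl amide in place of butyl amide on the shared core

The source may hold more compounds than are shown below. What is called first, only, known or untested is meant among the compounds shown, and "the series" means these compounds.

Compound 1, `CCCCCN1C(=O)C/C(=C\c2cccc(C(=O)NCCCC)c2)C1=O`, is one of three analogues examined in an ADME assay on NCM460 cells (Homo sapiens) for cytotoxicity, read by MTT assay, with a stated time of 72 h; on this read-out higher numbers stand for weaker inhibition and lower numbers for stronger inhibition. In this assay compound 1 gives > 100000 nM, which is a limit of the assay and not a number. Compound 2, `O=C(Nc1ccc(F)cc1)c1cccc(/C=C2\CC(=O)N(c3ccccc3)C2=O)c1`, gives > 100000 nM, again a limit. Compound 3, `CCCCNC(=O)c1cccc(/C=C2\CC(=O)N(Cc3ccccc3)C2=O)c1`, gives > 100000 nM, likewise a limit. The step that the two limits leave unreadable from compound 1 to compound 3 therefore has no readable size. Within the data shown here, the only evidence on hand is the limit of > 100000 nM in this assay, at which 3 of the 3 values shown sit: no value stands away from the limit, so no measured step carries a size that could be carried over.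

Compound 4, `CCCCCN1C(=O)C/C(=C\c2cccc(C(=O)Nc3ccc(C)cc3)c2)C1=O`, differs from compound 1 in one place: 4-methylphenyl in place of butyl on an amide-type nitrogen. Among the measured compounds shown here, no measured step covers this change directly. Compound 2 is the nearest analogue in which the amide-type nitrogen bears a six-membered aromatic ring rather than butyl, yet compound 2 differs from compound 4 in a second place too, so its limit is only loosely informative. With every value at the limit, the expected step of a number no higher from compound 1 to compound 4 (the limit leaves the size open) is none readable beyond the scatter. Compound 4 is therefore estimated at 100000 nM in this assay, with an expected range from 50000 nM to 200000 nM, and most probably reported only as a limit.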

Compound 4, half-maximal inhibitory concentration: > 100000 nM
Compound 4: a limit, no number; the forecaster's own chance of this, stated with the estimate: 85%; the middle value sits exactly at the limit.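

In this assay compound 4 gives > 100000 nM, a limit of the assay and not a number. Compound 1 also stands at a limit, so no step between compound 1 and compound 4 can be read: the limit of > 100000 nM in this assay, at which 4 of the 4 values shown sit.

The compounds shown leave open what size any step on the shared core would have in this assay.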